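Series notes: ester variation on the shared core

A few compounds are considered here, and "the series" means these few. Any claim that something is new, unique, unknown or untested is made for them only; others in the source may bear on it.

Compound 1 `NCc1ccc(C(=O)Nc2ccncc2F)cc1-c1cccc(C(=O)Oc2ccccc2)c1` gives 6.2 nM in an assay on isolated protein for inhibition of Rho-associated protein kinase 2 (Homo sapiens), read by radiometric assay (a higher number here means a weaker inhibitor, a lower number a stronger inhibitor), the lowest of the three numbers; compound 2 `CCCCCCOC(=O)c1cccc(-c2cc(C(=O)Nc3ccncc3)ccc2CN)c1` gives 22 nM and compound 3 `NCc1ccc(C(=O)Nc2ccncc2)cc1-c1cccc(C(=O)OCC2CCCCC2)c1` gives 48 nM in this assay. Compound 4 `NCc1ccc(C(=O)Nc2ccncc2F)cc1-c1cccc(C(=O)OCC2CC2)c1` differs from compound 1 by cyclopropylmethyl in place of phenyl on an oxygen next to a carbonyl group. Going by the values given here, no measured step exchanges a phenyl ester for an alkyl ester, so only the ester steps among the others bear on it: the change a 2.2-fold higher number from compound 2 to compound 3 (0.34 log units; beyond the scatter) is modest, and compound 2 and compound 3 each differ from compound 1 in two places, so their gap cannot be assigned to the ester alone. A modest rise in the number is expected for compound 4, as the step of a 2.4-fold higher number from compound 1 to compound 4 (0.38 log units; beyond the scatter). Compound 4 is therefore estimated at 15 nM in this assay, within 5 nM to 45 nM.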

Compound 4, half-maximal inhibitory concentration: 2.7 nM
Beside the measured number, compound 4's estimate is 5.6-fold (0.74 log units) above it; the measured number lies below the stated range.
By their numbers in this assay, from the lowest: compound 4; then compound 1; then compound 2; then compound 3.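

In this assay, the step of a 2.3-fold lower number from compound 1 to compound 4 (0.36 log units; beyond the scatter) shows that the phenyl ester is not needed at this position: cyclopropylmethyl, with fewer heavy atoms and no aromatic ring, serves at least as well on the core of compound 1. Going by these compounds alone, this is the first step here that exchanges an aromatic ester group for a saturated one, whereas the only earlier step, a 2.2-fold higher number from compound 2 to compound 3 (0.34 log units; beyond the scatter), exchanged one saturated group for another. Nothing on hand accounts for the direction of this step.

Open, from the compounds shown here alone, is how a carboxylic acid or an amide would read at this place, and whether a longer chain on the oxygen would keep the number this low on the core of compound 1.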